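Swapping an Ester for a Chlorophenyl on the Thiazole

The source may report more compounds than this note shows. Statements on the series, on what has been measured and on what is new or still open speak of the compounds shown alone.

Two measured compounds share one core and differ only in the ring attached to an amide-type nitrogen. Compound 1 `NS(=O)(=O)NCCCC[C@H](NC(=O)OCc1ccccc1)C(=O)Nc1nc2ccccc2s1` is the stronger of the pair: in an assay for inhibition of protein deacetylase HDAC6 (Homo sapiens) (a lower number here means a stronger inhibitor, a higher number a weaker inhibitor), compound 1 gives 190 nM. Compound 2 `CCOC(=O)c1csc(NC(=O)[C@H](CCCCNS(N)(=O)=O)NC(=O)OCc2ccccc2)n1` carries a different ring there, and in this assay compound 2 gives 580 nM. For the measured compounds named here, the single measured step, a 3.1-fold higher number from compound 1 to compound 2 (0.48 log units; beyond the scatter), shows that this exchange weakened inhibition, so compound 2 stands at the highest number of the two.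

Compound 3 `NS(=O)(=O)NCCCC[C@H](NC(=O)OCc1ccccc1)C(=O)Nc1nc(-c2ccc(Cl)cc2)cs1` keeps the ring of compound 2 but changes what sits on it: 4-chlorophenyl in place of ethoxycarbonyl on an aromatic carbon. Going by the values given here, no measured step covers this exchange directly. Among the compounds with values here, the only known step, a 3.1-fold higher number from compound 1 to compound 2 (0.48 log units; beyond the scatter), tells that leaving the group of compound 1 for the ester-bearing ring of compound 2 raised the number; compound 3 carries an aromatic ring once more, which is taken here as a pointer back toward compound 1 rather than as proof. The expected step is therefore a modest lowering, a 1.9-fold lower number from compound 2 to compound 3 (0.29 log units; within the scatter), with the possibility of no change beyond the scatter. Compound 3 is estimated at 300 nM, within a range from 100 nM to 900 nM.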

Compound 3, half-maximal inhibitory concentration: 250 nM
Compound 3: the middle estimate sits 1.2-fold (0.08 log units) above what was measured; the measured number falls inside the stated range.
By their numbers in this assay, from the lowest: compounds 1 and 3 (each within the scatter of the next); then compound 2.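

In this assay, this place on the thiazole ring proves sensitive on its own: with the rest of the molecule unchanged, 4-chlorophenyl in place of ethoxycarbonyl gives a 2.3-fold lower number from compound 2 to compound 3 (0.37 log units; beyond the scatter). The comparison with the fused ring of compound 1 adds a second point, since the exchange of 1,3-benzothiazol-2-yl for 4-(4-chlorophenyl)-1,3-thiazol-2-yl gives a 1.3-fold higher number from compound 1 to compound 3 (0.12 log units; within the scatter), so among these three compounds the higher number of compound 2 goes with its ethoxycarbonyl group and not with the thiazole ring as such. No supporting measurement is available to say why the number moves with this group.

As far as these compounds go, whether the lower number in compound 3 goes with the aromatic ring of the 4-chlorophenyl group or with its chlorine stays open, and a plain phenyl group at the same carbon would separate the two. From the compounds shown here alone, how far the number can travel at this place also remains unknown, and a carboxylic acid or an amine there would test it with groups of quite another kind.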